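Swapping the Aryl Group on a Sulfonyl Sulfur

The source may hold more compounds than are shown below. What is called first, only, known or untested is meant among the compounds shown, and "the series" means these compounds.

In a functional assay on A2780 cells (Homo sapiens) for inhibition, read by sulforhodamine B assay, with a stated time of 72 h (on this read-out higher numbers stand for weaker inhibition and lower numbers for stronger inhibition), compound 1 `Cc1ccccc1S(=O)(=O)c1ccc(CNC(=O)c2cc3cnccc3[nH]2)cc1` gives 13 nM. Compound 3 `O=C(NCc1ccc(S(=O)(=O)c2ccccc2)cc1)c1nc2cnccc2[nH]1` gives 5400 nM, which leaves compound 1 with the lower of the two exact numbers in this small set. Compound 2 `O=C(NCc1ccc(S(=O)(=O)c2ccccc2)cc1)c1ccc2ncncc2c1` is recorded only as a limit of the assay, > 10000 nM.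

Compound 4 `O=C(NCc1ccc(S(=O)(=O)c2ccc(F)c(F)c2)cc1)c1cc2cnccc2[nH]1` keeps the core of compound 1 and has 3,4-difluorophenyl in place of 2-methylphenyl on a sulfonyl sulfur. Within the data shown here, compound 2 and compound 3 differ from compound 1 in more than one place, so no measured pair isolates this swap. The best guide is therefore compound 1 itself, at 13 nM, whose core compound 4 retains. On that basis, the expected step of a 1.3-fold lower number from compound 1 to compound 4 (0.11 log units; within the scatter) is small and not beyond the usual scatter of this assay, with no firm direction. For compound 4 the estimated value is 10 nM, with an expected range from 3 nM to 40 nM.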

Compound 4, half-maximal inhibitory concentration: 14 nM
Beside the measured number, compound 4's estimate is 1.4-fold (0.15 log units) below it; measured number inside the range.
By their numbers in this assay, from the lowest: compounds 1 and 4 (each within the scatter of the next); then compound 3. At a limit, above all of these: compound 2.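

Replacing 2-methylphenyl with 3,4-difluorophenyl on a sulfonyl sulfur gives, in this assay, a 1.1-fold higher number from compound 1 to compound 4 (0.03 log units; within the scatter). Among these compounds, compound 1 and compound 4 are the first pair here that differ in one place only, so they give the first direct reading of this position. With the shared core held fixed, one substituted phenyl ring can take the place of the other with no change beyond the scatter. Nothing shown here accounts for why these two groups read alike.

As far as these compounds go, a single pair cannot show how far this tolerance extends, so it remains open whether an aliphatic group such as cyclohexyl, or a ring carrying an amine or a carboxylic acid, would behave the same way on the sulfonyl sulfur. Unsubstituted phenyl on the core of compound 1 is also an open case.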